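Dichlorophenyl pattern change in a fatty acid synthase series

A few compounds are considered here, and "the series" means these few. Any claim that something is new, unique, unknown or untested is made for them only; others in the source may bear on it.

Measured so far:
compound 1 `O=[N+]([O-])c1ccc2nc(O)c(-c3ccccc3)c(O)c2c1` — 550 nM
compound 2 `O=[N+]([O-])c1cc2c(O)c(-c3ccc(Cl)cc3Cl)c(O)nc2cc1Cl` — 443 nM

In an assay on isolated protein for inhibition of fatty acid synthase (Rattus norvegicus) (a higher number here means a weaker inhibitor, a lower number a stronger inhibitor), compound 1 gives 550 nM and compound 2 gives 443 nM. These two numbers cannot be told apart within the scatter of repeated measurements, so neither compound can be called the stronger or weaker inhibitor on present data; compound 2 simply sits alongside compound 1 at the same level.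

Compound 3 `O=[N+]([O-])c1cc2c(O)c(-c3cc(Cl)cc(Cl)c3)c(O)nc2cc1Cl` is the next case. It keeps every atom of compound 2 and changes only the arrangement: 3,5-dichlorophenyl in place of 2,4-dichlorophenyl on an aromatic carbon. Among the compounds with values here, no measured pair in this set rearranges the chlorines on the pendant ring, and the two compounds measured so far differ in several places at once, so there is no single step to lean on for this kind of change. The expectation for the step from compound 2 to compound 3 is therefore no shift beyond the scatter in either direction, a 1.1-fold higher number from compound 2 to compound 3 (0.05 log units; within the scatter). Compound 3 is expected to give 500 nM in this assay, with a plausible range from 200 nM to 1300 nM.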

Compound 3, half-maximal inhibitory concentration: 134 nM
For compound 3 the middle estimate is 3.7-fold (0.57 log units) above the measured one, and the stated range ends above it.
By their numbers in this assay, from the lowest: compound 3; then compounds 2 and 1 (each within the scatter of the next).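

In this assay, within the data shown here, rearranging the chlorines on the pendant ring, with 3,5-dichlorophenyl in place of 2,4-dichlorophenyl, gives a 3.3-fold lower number from compound 2 to compound 3 (0.52 log units; beyond the scatter) and is the first single-place step. The earlier pair differs in several places at once and could not isolate any one change, whereas this step shows that the arrangement of the two chlorines alone can move the number beyond the scatter at this position, since the entering and leaving groups have the same heavy-atom count and composition. The data offer no measurement that accounts for this shift.

This single pair cannot separate the loss of the 2,4-dichlorophenyl arrangement from the gain of the 3,5-dichlorophenyl arrangement, and it does not show whether the step would carry over to the core of compound 1. Also open, going by these compounds, is whether the 3,5-dichlorophenyl result depends on chlorine itself, a question that methyl or methoxy groups in place of the chlorines, or a single chlorine on the pendant ring, would address.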